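A few compounds are considered here, and "the series" means these few. Any claim that something is new, unique, unknown or untested is made for them only; others in the source may bear on it.

In a functional assay on A-375 cells (Homo sapiens) for cytotoxicity, read by CCK-8 assay, with a stated time of 24 h (a higher number here means a weaker inhibitor, a lower number a stronger inhibitor), three compounds have been measured. Compound 1 `COc1ccccc1Oc1c(N)nc(-c2cccc(Cl)c2)nc1Cl` gives 38300 nM. Compound 2 `COc1ccccc1Oc1c(N)nc(Cc2ccccc2)nc1OCCO` gives 200 nM. Compound 3 `COc1ccccc1Oc1c(N)nc(-c2ccccc2F)nc1OCCO` stands at the limit of > 80000 nM in this assay, at which 1 of the 3 values shown sits, so its reading of > 80000 nM is a limit of the assay and not a number.

Compound 4 `COc1ccccc1Oc1c(N)nc(-c2cccc(Cl)c2)nc1OCCO` keeps the 2-hydroxyethoxy group of compound 3 and changes one group, with 3-chlorophenyl in place of 2-fluorophenyl on an aromatic carbon. Within the data shown here, one measured step touches this same position, with 2-fluorophenyl in place of benzyl, and it shows an at least 400-fold higher number from compound 2 to compound 3 (2.60 log units; beyond the scatter). That step is large, so the group at this position can matter a great deal, yet it says nothing directly about 3-chlorophenyl. Compound 1 does carry 3-chlorophenyl, but not the 2-hydroxyethoxy group, and it gives a real number of 38300 nM. On that basis a lower number than the limit of compound 3 seems likely, though the size of the move is quite uncertain. The expected change is an at least 6.6-fold lower number from compound 3 to compound 4 (0.82 log units; beyond the scatter). Compound 4 is estimated at 12000 nM, with an expected range from 1000 nM to 80000 nM.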

Compound 4, half-maximal inhibitory concentration: 30200 nM
For compound 4 the middle estimate is 2.5-fold (0.40 log units) below the measured one, within the range that was stated.
By their numbers in this assay, from the lowest: compound 2; then compounds 4 and 1 (each within the scatter of the next). At a limit, above all of these: compound 3.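

On these data alone, compound 3 has no exact value, only a limit of the assay: the limit of > 80000 nM in this assay, at which 1 of the 4 values shown sits. The new result gives this position a second aryl reading, with an at least 2.6-fold lower number from compound 3 to compound 4 (0.42 log units; beyond the scatter), though this is only a minimum because compound 3 sits at that limit, so the true size of the step is unknown. Even so, 3-chlorophenyl does not come close to benzyl, with a 150-fold higher number from compound 2 to compound 4 (2.18 log units; beyond the scatter), so in these compounds the low number belongs to benzyl alone, and both groups with the aromatic ring attached directly to the shared core, 2-fluorophenyl and 3-chlorophenyl, read far higher. The group on the other side of the core adds a further point: with 3-chlorophenyl in place, a 1.3-fold lower number from compound 1 to compound 4 (0.10 log units; within the scatter), so chloro and 2-hydroxyethoxy cannot be told apart in this pair.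

Still open, as far as these compounds go, is whether benzyl would keep its low number with a chloro or fluoro substituent on its ring, which would show if the single carbon link matters more than the ring substituents. A longer chain such as 2-phenylethyl, or an amine at this position, would test how far that link can be changed.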